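A few compounds are considered here, and "the series" means these few. Any claim that something is new, unique, unknown or untested is made for them only; others in the source may bear on it.

In a functional assay on MDA-MB-231 cells (Homo sapiens) for cytotoxicity, read by MTT assay, with a stated time of 72 h (a lower number here means a stronger inhibitor, a higher number a weaker inhibitor), compound 2 `O=C(CN1CCN(c2nnc(Cc3ccncc3)c3ccccc23)CC1)Nc1ccc(Br)cc1` gives 19 nM, the lower of the two numbers measured, while compound 1 `Cc1ccc(NC(=O)CN2CCN(c3nnc(Cc4ccncc4)c4ccccc34)CC2)c(C)c1` gives 240 nM. Compound 3 `O=C(CN1CCN(c2nnc(Cc3ccncc3)c3ccccc23)CC1)Nc1cccc(F)c1` differs from compound 2 at one place: 3-fluorophenyl in place of 4-bromophenyl on an amide-type nitrogen. Among the compounds with values here, the only measured step bearing on this change lies on the same amide-type nitrogen, a 13-fold lower number from compound 1 to compound 2 (1.10 log units; beyond the scatter), and it is large, showing that the group there can move the number well beyond the scatter. Within the data shown here, no measured compound carries 3-fluorophenyl, and a moderate rise in this assay is expected, with wide uncertainty. The expected step is a 3.2-fold higher number from compound 2 to compound 3 (0.50 log units; beyond the scatter). For compound 3 the estimated value is 60 nM, with an expected range of 15 nM to 240 nM.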

Compound 3, half-maximal inhibitory concentration: 4.4 nM
For compound 3 the middle estimate is 14-fold (1.13 log units) above the measured one; measured number outside the range, below it.
By their numbers in this assay, from the lowest: compound 3; then compound 2; then compound 1.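

In this assay, the bromine of compound 2 proves not to be needed for a low number at this amide-type nitrogen: 3-fluorophenyl in place of 4-bromophenyl gives a 4.3-fold lower number from compound 2 to compound 3 (0.64 log units; beyond the scatter). Against 2,4-dimethylphenyl, the same group gives a 55-fold lower number from compound 1 to compound 3 (1.74 log units; beyond the scatter), so 3-fluorophenyl carries the lowest number of the three groups. The 4-bromophenyl to 3-fluorophenyl step changes both the halogen and the ring position, and these two changes cannot be told apart. How a chlorine, a methoxy group or an amine on this phenyl ring would read stays open, and no measurement shown accounts for the differences.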